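A Larger Ring on the Amine Side Chain

The source may report more compounds than this note shows. Statements on the series, on what has been measured and on what is new or still open speak of the compounds shown alone.

Compound 1 `c1cnc2c(c1)CCC[C@@H]2N(CC1CC1)C[C@H]1Cc2c(cccc2N2CCNCC2)CN1` belongs to a set of three compounds on a shared core that were tested in a functional assay on CCRF-CEM cells for agonist activity at C-X-C chemokine receptor type 4 (Homo sapiens), read by calcium flux, with a stated time of 25 min; a higher number here means that more compound is needed for the effect, a lower number that less compound is needed. For compound 1 this assay gives only a limit, > 30000 nM. Compound 2 `CC(C)N1CCN(c2cccc3c2C[C@H](CN(C)[C@H]2CCCc4cccnc42)NC3)CC1` likewise returns a limit, > 30000 nM. Compound 3 `CN(C[C@H]1Cc2c(cccc2N2CCN3CCC[C@@H]3C2)CN1)[C@H]1CCCc2cccnc21` also returns a limit, > 30000 nM. Among the measured compounds shown here, the one step between measured neighbours, a step that the two limits leave unreadable from compound 2 to compound 3, cannot be read as a size, and it sits at another place on the core; all three values rest at the same point (the limit of > 30000 nM in this assay, at which 3 of the 3 values shown sit). Compound 4 `c1cnc2c(c1)CCC[C@@H]2N(CC1CCCCC1)C[C@H]1Cc2c(cccc2N2CCNCC2)CN1` differs from compound 1 by cyclohexyl in place of cyclopropyl on a saturated chain carbon bound to an amine nitrogen. For the measured compounds named here, no measured step touches this change, so no direction can be drawn from the data. One therefore expects compound 4 to stay near the limit, with a number no higher from compound 1 to compound 4 (the limit leaves the size open) amounting to no readable step, and estimates 30000 nM in the range 10000 nM to 100000 nM.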

Compound 4, half-maximal effective concentration: > 30000 nM
Compound 4 gave a limit, no number; the forecaster's own chance of this, stated with the estimate: 80%; the middle value lies on the limit itself.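

Compound 1 and compound 4 both return only a limit, so no step can be read between them: the limit of > 30000 nM in this assay, at which 4 of the 4 values shown sit. The compounds shown leave open whether any change on the shared core gives a measurable value.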